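Removing the Pyrrolidine from Compound 3

The compounds below may be only part of what the source reports. "The series", "measured", "known", "first", "only" and "open" are said of these compounds alone.

Compound 1 `O=C(O)CCC(=O)Nc1ccc(-c2nc3cc(C(F)(F)F)ccc3[nH]2)cc1`, compound 2 `CC(=O)Nc1ccc(-c2nc3cc([N+](=O)[O-])ccc3[nH]2)cc1` and compound 3 `O=C(CN1CCCC1)Nc1ccc(-c2nc3ccccc3[nH]2)cc1` have been tested in an ADME assay on MT4 cells (Homo sapiens) for cytotoxicity, read by MTT assay, with a stated time of 96 h; a lower number here means that less compound is tolerated, a higher number that more compound is tolerated. Compound 1 gives > 100000 nM, which is a limit of the assay rather than a number. Compound 2 gives > 100000 nM, again a limit and not a number. Going by the values given here, compound 3 gives 40000 nM, the only true number among the three, as the other two values sit at the limit of > 100000 nM in this assay, at which 2 of the 3 values shown sit. Compound 4 `CC(=O)Nc1ccc(-c2nc3ccccc3[nH]2)cc1` has not yet been measured in this assay. It differs from compound 3 in one place: hydrogen in place of pyrrolidin-1-yl on a saturated chain carbon bound to a carbonyl carbon. Among the compounds with values here, no measured step of this kind exists among the three compounds, so the step of a 2.5-fold higher number from compound 3 to compound 4 (0.40 log units; beyond the scatter) is expected to be modest and, if anything, toward greater tolerance. Compound 4 is therefore estimated at 100000 nM, within 40000 nM to 300000 nM.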

Compound 4, half-maximal cytotoxic concentration: 100000 nM
Compound 4: the middle estimate sits on the measured number at the digits printed; measured number inside the range.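

Going by these compounds alone, replacing pyrrolidin-1-yl with hydrogen on the saturated chain carbon bound to a carbonyl carbon gives a 2.5-fold higher number from compound 3 to compound 4 (0.40 log units; beyond the scatter), the first step whose size can be read. For this pair, the pyrrolidin-1-yl group goes with less compound being tolerated. The other step is a number no higher from compound 2 to compound 4 (the limit leaves the size open), and its size cannot be read. Compound 2 stands at a limit and not a number: the limit of > 100000 nM in this assay, at which 2 of the 4 values shown sit.

From the compounds shown here alone, it remains open whether this step depends on the pyrrolidine itself. A piperidine, a morpholine or an open-chain amine on the same carbon would test that.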